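From Methyl to Methylsulfanyl on a Shared Core

The compounds below may be only part of what the source reports. "The series", "measured", "known", "first", "only" and "open" are said of these compounds alone.

Three compounds share one core and differ in a single group. In a physicochemical assay for lipophilicity (on this read-out lower numbers stand for lower lipophilicity and higher numbers for higher lipophilicity), compound 1 `CCOc1ccccc1C1=NC(c2ccccc2)CO1` gives 4.22, compound 2 `CCSc1ccccc1C1=NC(c2ccccc2)CO1` gives 4.04, and compound 3 `Cc1ccccc1C1=NC(c2ccccc2)CO1` gives 3.68, the lowest of the three.

The next compound, compound 4 `CSc1ccccc1C1=NC(c2ccccc2)CO1`, has methylsulfanyl in place of methyl on an aromatic carbon. Among the measured compounds shown here, no measured pair tests this exact swap, so the nearest evidence comes from the related ethylsulfanyl group. The most relevant comparison is a number 0.36 log units lower from compound 2 to compound 3 (beyond the scatter), which replaces ethylsulfanyl with methyl. Placing methyl where ethoxy stood gave a somewhat larger change, a number 0.54 log units lower from compound 1 to compound 3 (beyond the scatter), while ethylsulfanyl in place of ethoxy gave only a number 0.18 log units lower from compound 1 to compound 2 (within the scatter).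

Compound 4 differs from compound 2 only in having methyl rather than ethyl on the sulfur, so it is expected to fall between compound 3 and compound 2, nearer compound 3. The expected change is small and upward, a number 0.10 log units higher from compound 3 to compound 4 (within the scatter), and it is not expected to exceed the usual scatter. For compound 4, the estimated value in this assay is 3.78, with an expected range from 3.48 to 4.08.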

Compound 4, partition coefficient: 3.5
Compound 4: the middle estimate sits 0.28 log units above what was measured; the measured number falls inside the stated range.
By their numbers in this assay, from the lowest: compounds 4 and 3 (each within the scatter of the next); then compounds 2 and 1 (each within the scatter of the next).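

On this aromatic carbon, ortho to a large group, methylsulfanyl in place of methyl brings in a sulfur, yet this assay gives a step (a number 0.18 log units lower from compound 3 to compound 4 (within the scatter)) that leaves the two groups indistinguishable. Within the sulfur-bearing chain, however, removing the end methyl so that ethylsulfanyl becomes methylsulfanyl gives a step beyond the scatter (a number 0.54 log units lower from compound 2 to compound 4 (beyond the scatter)), so a small edit to the chain on the sulfur registers on this read-out even though the swap from methyl does not. Methylsulfanyl in place of ethoxy also gives a clear step (a number 0.72 log units lower from compound 1 to compound 4 (beyond the scatter)), but nothing available here accounts for the size of any of these steps.

The compounds shown carry only methyl, ethoxy, ethylsulfanyl and methylsulfanyl at this position, so it remains open how a methoxy group, a longer chain on the sulfur or an amine would compare. Going by these compounds, it also remains open whether these swaps would give steps of similar size elsewhere on the shared core.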